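The compounds below may be only part of what the source reports. "The series", "measured", "known", "first", "only" and "open" are said of these compounds alone.

Measured compounds:
compound 1 `NC1=NC2(CCSCC2)N(OCCCOc2cccc(Cl)c2Cl)C(N)=N1`, 30 nM
compound 2 `NC1=NC2(CCOCC2)N(OCCCOc2ccc(Cl)cc2)C(N)=N1`, 330 nM
compound 3 `NC1=NC2(CCSCC2)N(OCCCOc2ccc(Br)cc2)C(N)=N1`, 350 nM

In a functional assay on HL-60 cells (Homo sapiens) for antiproliferative activity, read by MTT assay, with a stated time of 72 h (a higher number here means a weaker inhibitor, a lower number a stronger inhibitor), compound 2 gives 330 nM, the second highest of the three numbers; compound 3 at 350 nM lies within the scatter of it, while compound 1 at 30 nM lies well below. The unmeasured compound 4 `NC1=NC2(CCOCC2)N(OCCCOc2ccccc2)C(N)=N1` differs from compound 2 by hydrogen in place of chloro on an aromatic carbon. Within the data shown here, the only step that touches the same phenoxy group is a 12-fold higher number from compound 1 to compound 3 (1.07 log units; beyond the scatter), where the ring lost both chlorines and gained a bromine; no step shows a halogen removed outright. Taking that step as the nearest guide, compound 4 is expected to give a somewhat higher number than compound 2, with the step of a 2.4-fold higher number from compound 2 to compound 4 (0.38 log units; beyond the scatter) estimated; the estimate for compound 4 is 800 nM, from 300 nM to 3000 nM.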

Compound 4, half-maximal inhibitory concentration: 2460 nM
Compound 4: middle estimate off by 3.1-fold (0.49 log units), on the low side; the measured number falls inside the stated range.
By their numbers in this assay, from the lowest: compound 1; then compounds 2 and 3 (each within the scatter of the next); then compound 4.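

In this assay, hydrogen in place of chloro gives a 7.5-fold higher number from compound 2 to compound 4 (0.87 log units; beyond the scatter) and so shows that this one atom, on an aromatic carbon para to a large group, moves the number beyond the scatter by itself. The earlier step from compound 1 to compound 3 changed the whole halogen pattern at once and could not show the effect of a single halogen. Nothing measured here explains the size of this step.

As far as these compounds go, whether an amine, a methoxy group or a nitrile in this place would match chloro remains open. So does whether the same change gives a like step on the core of compound 1.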